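Side-Chain Exchange on an Amino Ester Amide Tail

The compounds below may be only part of what the source reports. "The series", "measured", "known", "first", "only" and "open" are said of these compounds alone.

Measured compounds:
Compound 1, `COC(=O)[C@H](NC(=O)Cn1cc(C2=C(c3c[nH]c4ccccc34)C(=O)N(C)C2=O)c2ccccc21)[C@@H](C)O`, gives 21400 nM in a functional assay on A2780 cells (Homo sapiens) for cytotoxicity, read by MTT assay, with a stated time of 24 h; on this read-out lower numbers stand for stronger inhibition and higher numbers for weaker inhibition.
Compound 2, `COC(=O)CC[C@@H](NC(=O)Cn1cc(C2=C(c3c[nH]c4ccccc34)C(=O)N(C)C2=O)c2ccccc21)C(=O)OC`, gives 32300 nM in this assay.

Among the compounds with values here, of the two numbers in this assay, compound 2 holds the larger one, with compound 1 as its only neighbour; yet a 1.5-fold higher number from compound 1 to compound 2 (0.18 log units; within the scatter) falls within the scatter, so the two compounds cannot be told apart on this read-out.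

Compound 3, `COC(=O)[C@@H](CC(C)C)NC(=O)Cn1cc(C2=C(c3c[nH]c4ccccc34)C(=O)N(C)C2=O)c2ccccc21`, has not yet been measured in this assay. It differs from compound 2 by isopropyl in place of (methoxycarbonyl)methyl on a saturated chain carbon, two bonds along the chain from an amide-type nitrogen and a carbonyl carbon. Within the data shown here, the only measured step that bears on this change is a 1.5-fold higher number from compound 1 to compound 2 (0.18 log units; within the scatter), which likewise altered the substituent on the amino-ester carbon of the tail and stayed within the scatter. On that basis compound 3 is expected to sit close to compound 2, with a 1.2-fold lower number from compound 2 to compound 3 (0.08 log units; within the scatter) as the anticipated step, no movement beyond the scatter in either direction. Compound 3 is therefore estimated at 27000 nM in this assay, with a range from 11000 nM to 65000 nM.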

Compound 3, half-maximal inhibitory concentration: 38500 nM
Compound 3: middle estimate off by 1.4-fold (0.15 log units), on the low side; the range from low to high includes it.
By their numbers in this assay, from the lowest: compounds 1, 2 and 3 (each within the scatter of the next).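

In this assay, isopropyl in place of (methoxycarbonyl)methyl takes away the ester's 5 heavy atoms' worth of group, with its 2 hydrogen-bond acceptors, and leaves a group of 3 carbon atoms with none, yet this gives only a 1.2-fold higher number from compound 2 to compound 3 (0.08 log units; within the scatter). Within the data shown here, the widest step among the three side chains, isobutyl in place of 1-hydroxyethyl on the saturated chain carbon bound to an amide-type nitrogen and a carbonyl carbon, is a 1.8-fold higher number from compound 1 to compound 3 (0.26 log units; within the scatter), so a purely hydrocarbon side chain, a hydroxyl-bearing one and an ester-bearing one cannot be told apart on this read-out, something the single earlier step could not show for a side chain without any hydrogen-bond acceptors. Nothing at hand accounts for this flat result.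

The three compounds leave open whether any side chain at this carbon can move the number beyond the scatter, for instance a primary amine, a free carboxylic acid or a phenyl ring. They also leave open whether a change to the methyl ester itself, such as its replacement by a carboxylic acid or a primary amide, would matter more than the side chain does.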